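A few compounds are considered here, and "the series" means these few. Any claim that something is new, unique, unknown or untested is made for them only; others in the source may bear on it.

Working notes: measured compounds in a functional assay on PC-3 cells (Homo sapiens) for cytotoxicity, read by MTT assay, with a stated time of 72 h; a lower number here means a stronger inhibitor, a higher number a weaker inhibitor
- Compound 1 `COc1cc(/C=C/C(O)=C/C(=O)/C=C/C2=C(C)CCCC2(C)C)ccc1O`: 15800 nM
- Compound 2 `COc1cc(/C=C(\C(=O)/C=C/C2=C(C)CCCC2(C)C)C(=O)/C=C/c2ccc(O)c(OC)c2)ccc1O`: 4200 nM
- Compound 3 `COc1ccc(/C=C/C(O)=C/C(=O)/C=C/C2=C(C)CCCC2(C)C)cn1`: 52200 nM

Compound 3, at 52200 nM, has the highest number of the three. Compound 1 lies nearest to it at 15800 nM, and compound 2 lies furthest at 4200 nM.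

The next entry is compound 4 `COc1ccc(/C=C/C(O)=C/C(=O)/C=C/C2=C(C)CCCC2(C)C)cc1O`, not yet measured. The structural change is 3-hydroxy-4-methoxyphenyl in place of 6-methoxypyridin-3-yl on a double-bonded chain carbon bound to a double-bonded chain carbon.

For the measured compounds named here, one measured step bears on this change: a 3.3-fold higher number from compound 1 to compound 3 (0.52 log units; beyond the scatter). That step put 6-methoxypyridin-3-yl in place of 4-hydroxy-3-methoxyphenyl at the same place in the chain. Compound 4 goes back to a carbon-only aromatic ring carrying a hydroxy and a methoxy group, as in compound 1, though the group is 3-hydroxy-4-methoxyphenyl rather than 4-hydroxy-3-methoxyphenyl. The step from compound 1 is therefore read in reverse as the best available guide in this assay, and a lower number of similar size is expected. Going by the values given here, no measured pair compares these two hydroxy-methoxy arrangements, so the range is kept wide.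

The expected change is a 3.1-fold lower number from compound 3 to compound 4 (0.49 log units; beyond the scatter). The estimated value for compound 4 is 17000 nM, with an expected range of 6500 nM to 42000 nM.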

Compound 4, half-maximal inhibitory concentration: 38300 nM
The estimate for compound 4 lay 2.3-fold (0.35 log units) below the measured number; the range from low to high includes it.
By their numbers in this assay, from the lowest: compound 2; then compound 1; then compounds 4 and 3 (each within the scatter of the next).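

In this assay, the step of a 2.4-fold higher number from compound 1 to compound 4 (0.38 log units; beyond the scatter) shows that this position responds to the arrangement of the hydroxy and methoxy groups on the carbon-only ring, not just to their presence, since 4-hydroxy-3-methoxyphenyl and 3-hydroxy-4-methoxyphenyl carry the same two groups. The step of a 1.4-fold lower number from compound 3 to compound 4 (0.13 log units; within the scatter) shows that a carbon-only ring with a hydrogen-bond donor does not by itself separate compound 4 from the 6-methoxypyridin-3-yl compound, and so does not by itself reproduce the number of compound 1, 15800 nM. Nothing available explains either step.

The compounds shown leave open whether the hydroxy group, the methoxy group or both drive the gap between compound 1 and compound 4, a question that rings bearing only one of these groups, or a 3,4-dimethoxyphenyl or amino-substituted ring, would address. They also leave open whether the arrangement in 3-hydroxy-4-methoxyphenyl would give the same result in the two-armed form of compound 2, which stands at 4200 nM with the 4-hydroxy-3-methoxyphenyl group.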